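Hydroxy to methoxy on compound 3: expected shift

A few compounds are considered here, and "the series" means these few. Any claim that something is new, unique, unknown or untested is made for them only; others in the source may bear on it.

Measured so far in a functional assay on HepG2 cells (Homo sapiens) for antiproliferative activity, read by sulforhodamine B assay, with a stated time of 48 h; a higher number here means a weaker inhibitor, a lower number a stronger inhibitor
- compound 1 `COc1ccc(OC)c(/C=C/C(=O)/C=C(O)/C=C/c2cc(OC)ccc2OC)c1` gives 5560 nM
- compound 2 `COc1cccc(/C=C/C(=O)C(=Cc2ccc(F)cc2)C(=O)/C=C/c2cccc(OC)c2OC)c1OC` gives 580 nM
- compound 3 `COc1cc(C=C(C(=O)/C=C/c2cccc(OC)c2OC)C(=O)/C=C/c2cccc(OC)c2OC)ccc1O` gives 200 nM

Compound 3 holds the lowest number of the three, and its gaps to compound 1 and compound 2 both lie beyond the scatter. Compound 4 `COc1ccc(C=C(C(=O)/C=C/c2cccc(OC)c2OC)C(=O)/C=C/c2cccc(OC)c2OC)cc1OC` is still to be measured in this assay and differs from compound 3 by methyl in place of hydrogen on an oxygen on an aromatic ring, so that 4-hydroxy-3-methoxyphenyl becomes 3,4-dimethoxyphenyl.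

Among the compounds with values here, no measured step shows this exact change. The closest evidence is a 2.9-fold lower number from compound 2 to compound 3 (0.46 log units; beyond the scatter), a modest step at the same aromatic group, with 4-hydroxy-3-methoxyphenyl in place of 4-fluorophenyl. Within the data shown here, compound 1 differs from the others in more than one place and offers no usable step. Compound 2, like compound 4, carries no hydroxy on that group, and it has the higher number of that pair. Among the measured compounds shown here, a small rise in the number is therefore expected, no larger than that step and possibly within the scatter. The expected change is a 1.7-fold higher number from compound 3 to compound 4 (0.22 log units; within the scatter), an estimate resting on a single step. Compound 4 is expected at 330 nM, with an estimated range of 120 nM to 900 nM.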

Compound 4, half-maximal inhibitory concentration: 200 nM
Beside the measured number, compound 4's estimate is 1.7-fold (0.22 log units) above it; low and high end bracket the measured number.
By their numbers in this assay, from the lowest: compounds 3 and 4 (each within the scatter of the next); then compound 2; then compound 1.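

In this assay, methyl in place of hydrogen on an oxygen on an aromatic ring gives no change at the digits printed from compound 3 to compound 4 (within the scatter), so the free hydroxy of the 4-hydroxy-3-methoxyphenyl group is not needed to hold the number of compound 3 in this series. The step of a 2.9-fold lower number from compound 2 to compound 4 (0.46 log units; beyond the scatter) is the same in size as a 2.9-fold lower number from compound 2 to compound 3 (0.46 log units; beyond the scatter), which shows that the lower number relative to the 4-fluorophenyl compound 2 does not depend on a hydroxy on this ring, at least for these two groups. No measurement shown here bears on why the methyl leaves the number in place.

Only hydrogen and methyl are shown on this oxygen, so it remains open whether a longer chain such as ethyl, or a chain ending in an amine or a carboxylic acid, would be accepted there in the same way. Within the data shown here, compound 1 differs from the others in more than one place and no step to it can be read, and the role of the methoxy shared by compound 3 and compound 4 also stays untested by these compounds.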